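Swapping a bromophenyl amide for a methylphenyl amide

The source may report more compounds than this note shows. Statements on the series, on what has been measured and on what is new or still open speak of the compounds shown alone.

Compound 1 `COc1ccc(-c2cnc(NC(=O)c3ccc(Br)cc3)n2C)cc1` belongs to a small set tested in a toxicity assay on THP-1 cells (Homo sapiens) for inhibition; on this read-out lower numbers stand for higher toxicity in this test and higher numbers for lower toxicity in this test. In this assay compound 1 gives > 100000 nM, which is a limit of the test rather than a measured number. Compound 2 `Cc1ccccc1-c1cnc(NC(=O)c2ccc(F)cc2)n1C` likewise stops at a limit, > 50000 nM, in this assay. Compound 3 `COc1ccc(-c2cnc(NC(=O)c3ccc(F)cc3)n2-c2ccccc2)cc1` gives a real number, 8800 nM, in this assay. Compound 4 `COc1ccc(-c2cnc(NC(=O)c3ccccc3C)n2C)cc1` has not been measured yet; it differs from compound 1 by 2-methylphenyl in place of 4-bromophenyl on a carbonyl carbon. Going by the values given here, no measured pair shows this exchange, and compound 1 itself sits at the limit of > 100000 nM in this assay, at which 1 of the 3 values shown sits, so no movement beyond the usual scatter is expected. The expected step of a number no higher from compound 1 to compound 4 (the limit leaves the size open) is therefore small. Compound 4 is estimated at 100000 nM, within a range from 30000 nM to 300000 nM, and may well again be reported only as a limit.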

Compound 4, half-maximal cytotoxic concentration: > 100000 nM
Compound 4 gave a limit, no number; the forecaster's own chance of this, stated with the estimate: 70%; the middle value lies on the limit itself.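

Compound 1 and compound 4 both stop at a limit of the test, and the step between them cannot be read. In this assay the compounds shown leave open whether 2-methylphenyl in place of 4-bromophenyl changes the result at all.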